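Trifluoromethyl for methoxy on an oral exposure series

The source may report more compounds than this note shows. Statements on the series, on what has been measured and on what is new or still open speak of the compounds shown alone.

Of the compounds shown here, three of one shared core have been measured in an ADME assay on the whole organism (Mus musculus, strain CD1) for pharmacokinetics, at a dose of 10 mg/kg by the oral route; a lower number here means less compound in the circulation, a higher number more compound in the circulation at the dose given. Compound 1 `N#Cc1ncc(N2C(=O)C3(CCC3)N(c3ccc(OC4CCNCC4)nc3)C2=S)cc1C(F)(F)F` gives 4900 ng.h/mL. Compound 2 `COc1cc(N2C(=O)C3(CCC3)N(c3ccc(OC4CCN(C)CC4)nc3)C2=S)cnc1C#N` gives 6100 ng.h/mL. Compound 3 `COc1cc(N2C(=O)C3(CCC3)N(c3ccc(OC4CCN(C)CC4)cc3)C2=S)cnc1C#N` gives 20100 ng.h/mL. Among these three numbers compound 2 stands second highest: compound 1 sits within the scatter of it, while compound 3 lies beyond the scatter, with the higher number of the pair.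

Compound 4 `CN1CCC(Oc2ccc(N3C(=S)N(c4cnc(C#N)c(C(F)(F)F)c4)C(=O)C34CCC4)cn2)CC1` has not been measured in this assay. It differs from compound 2 in one place: trifluoromethyl in place of methoxy on an aromatic carbon. Among the compounds with values here, no step between measured compounds in this assay carries exactly this change, so its size is open. What the data offer is that compound 1, which also carries a trifluoromethyl where compound 2 carries a methoxy, falls within the scatter of compound 2. On that basis the step is expected to be small, in no clear direction, and likely to stay within the scatter.

Compound 4 is therefore expected to give about 5500 ng.h/mL in this assay, with a range from 2500 ng.h/mL to 12000 ng.h/mL. That estimate means a step of a 1.1-fold lower number from compound 2 to compound 4 (0.04 log units; within the scatter), expected to stay within the scatter, because compound 1 gives 4900 ng.h/mL close to compound 2.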

Compound 4, area under the concentration-time curve: 10900 ng.h/mL
Beside the measured number, compound 4's estimate is 2.0-fold (0.30 log units) below it, within the range that was stated.
By their numbers in this assay, from the lowest: compounds 1, 2, 4 and 3 (each within the scatter of the next, the first and the last beyond it).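

In this assay the exchange of methoxy for trifluoromethyl on the aromatic carbon ortho to a cyano group can now be read on its own: it gives a 1.8-fold higher number from compound 2 to compound 4 (0.25 log units; within the scatter) and so does not stand clear of the usual variation at this position. Compound 1 differs from compound 2 in two places, so its closeness to compound 2 could not speak for either change alone, whereas compound 4 separates them and shows that methyl in place of hydrogen on the amine nitrogen in the ring gives a 2.2-fold higher number from compound 1 to compound 4 (0.35 log units; beyond the scatter) as a modest step. Nothing available accounts for either step.

From the compounds shown here alone, each of these two changes is read only once, on a single partner, so it remains open whether either step would keep its size on another member of the series. Going by these compounds, it also remains open what a chlorine atom or an ethoxy group would give on the same aromatic carbon, and what an ethyl group would give on the amine nitrogen.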